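Working notes: fluoro in place of methoxy, compound 4

The compounds below may be only part of what the source reports. "The series", "measured", "known", "first", "only" and "open" are said of these compounds alone.

In a functional assay on MCF7 cells (Homo sapiens) for inhibition, read by MTT assay (on this read-out lower numbers stand for stronger inhibition and higher numbers for weaker inhibition), compound 1 (`O=C(COc1ccc(C(=O)/C=C/c2ccccc2)cc1)NO`) gives 620 nM and compound 2 (`COc1ccc(/C=C/C(=O)c2ccc(OCC(=O)NO)cc2)cc1`) gives 620 nM. Compound 3 (`Cc1ccc(-c2nnc(NC(=O)CCCCCCC(=O)NO)s2)s1`) gives 880 nM. Compound 2 is thus level with compound 1 and within the scatter of compound 3.

Compound 4 (`O=C(COc1ccc(C(=O)/C=C/c2ccc(F)cc2)cc1)NO`) has fluoro in place of methoxy on an aromatic carbon, para to a large group: fluoro in place of methoxy on an aromatic carbon. Among the measured compounds shown here, no fluoro compound has been measured yet. For the measured compounds named here, the only measured step bearing on this, methoxy in place of hydrogen, is no change at the digits printed from compound 1 to compound 2 (within the scatter), so no step beyond the scatter, in either direction, is expected in this assay. The estimated step is a 1.0-fold lower number from compound 2 to compound 4 (0.01 log units; within the scatter). Compound 4 is estimated at 600 nM, with an expected range of 280 nM to 1300 nM.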

Compound 4, half-maximal inhibitory concentration: 620 nM
Estimate against measurement, compound 4: 1.0-fold (0.01 log units) below; low and high end bracket the measured number.
By their numbers in this assay, from the lowest: compounds 1, 2, 4 and 3 (each within the scatter of the next).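

In this assay the aromatic carbon para to a large group now holds fluoro as well as methoxy and hydrogen, and the read-out does not separate them: no change at the digits printed from compound 2 to compound 4 (within the scatter) and no change at the digits printed from compound 1 to compound 4 (within the scatter). Fluoro in place of methoxy thus adds a second flat step at this position, and fluoro in place of hydrogen a third. No data at hand give a reason for this flatness.

Open, going by these compounds, is whether an amine or a carboxylic acid on this carbon would give a step beyond the scatter. The compounds shown contain no such step at this position, so any sensitivity of the read-out to this carbon remains unknown.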